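This account rests on a few compounds, and the source may have more. Where it says the series, first, only, none or still open, it means among the compounds named here.

Three members of the series have been read in an assay on HEK293 cells for positive allosteric modulation of metabotropic glutamate receptor 2 (Rattus norvegicus), read by thallium flux, with a stated time of 2.5 min; a higher number here means that more compound is needed for the effect, a lower number that less compound is needed. Compound 1 `Cc1c(OCCCCOc2ccc(C(=O)O)cc2)ccc(C(=O)CC2CCCC2)c1O` gives 824 nM. Compound 2 `COc1cc(C(=O)O)ccc1OCCCCOc1ccc(C(=O)CC(C)C)c(O)c1C` gives 40 nM. Compound 3 `Cc1c(OCCCCOc2ccc(C(=O)O)cc2F)ccc(C(=O)CC(C)C)c1O` gives 102 nM. Compound 3 therefore holds the second highest of the three numbers: the nearest is compound 2, the step of a 2.6-fold higher number from compound 2 to compound 3 (0.41 log units; beyond the scatter) setting the two apart, while compound 1 stands further off with a clearly higher number than compound 3.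

Compound 4 `Cc1c(OCCCCOc2ccc(C(=O)O)cc2)ccc(C(=O)CC(C)C)c1O` differs from compound 3 by hydrogen in place of fluoro on an aromatic carbon. Among the measured compounds shown here, only one measured step touches the same carbon: the step of a 2.6-fold higher number from compound 2 to compound 3 (0.41 log units; beyond the scatter), in which methoxy gave way to fluoro, a modest move. For the measured compounds named here, no measured pair shows fluoro against hydrogen at this position, and compound 1, which carries hydrogen there, also differs in the ketone side chain, so its value cannot be read as a clean guide. A step of modest size at most is therefore expected in this assay, direction uncertain, with a slight lean towards a higher number; the expected step is a 1.8-fold higher number from compound 3 to compound 4 (0.25 log units; within the scatter). For compound 4 the estimate is 180 nM, with a range from 60 nM to 550 nM.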

Compound 4, half-maximal effective concentration: 122 nM
Beside the measured number, compound 4's estimate is 1.5-fold (0.17 log units) above it, and the stated range covers the measured number.
By their numbers in this assay, from the lowest: compound 2; then compounds 3 and 4 (each within the scatter of the next); then compound 1.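

In this assay, among the compounds shown here, the first clean fluoro-to-hydrogen comparison at this aromatic carbon gives a 1.2-fold higher number from compound 3 to compound 4 (0.08 log units; within the scatter), so the change from 4-carboxy-2-fluorophenyl to 4-carboxyphenyl does not separate the two compounds. Methoxy at the same carbon now stands apart from hydrogen as well as from fluoro, with a 3.1-fold higher number from compound 2 to compound 4 (0.48 log units; beyond the scatter) alongside a 2.6-fold higher number from compound 2 to compound 3 (0.41 log units; beyond the scatter). With hydrogen held on this carbon, the ketone side chain also gets a clean reading, with isopropyl in place of cyclopentyl giving a 6.8-fold lower number from compound 1 to compound 4 (0.83 log units; beyond the scatter).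

No measurement shown here accounts for what sets methoxy apart from fluoro and hydrogen. Still open, as far as these compounds go, are how a hydroxy group, a chlorine atom or an ethoxy group would read on this aromatic carbon, and whether methoxy would keep its standing with cyclopentyl on the side chain.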